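A few compounds are considered here, and "the series" means these few. Any claim that something is new, unique, unknown or untested is made for them only; others in the source may bear on it.

Measured in a functional assay on HEp-2 cells (Homo sapiens) for inhibition; on this read-out higher numbers stand for an effect only at larger amounts of compound and lower numbers for an effect already at smaller amounts:
Compound 1 `CSc1ncnc2c1nnn2[C@@H]1O[C@H](CO)[C@@H](O)[C@H]1O`: 0.02 uM
Compound 2 `CCOc1ncnc2c1nnn2[C@@H]1O[C@H](CO)[C@@H](O)[C@H]1O`: 0.1 uM

Compound 2 holds the higher of the two numbers. Compound 3 `CCCCNc1ncnc2c1nnn2[C@@H]1O[C@H](CO)[C@@H](O)[C@H]1O` has butylamino in place of ethoxy on an aromatic carbon. Among the measured compounds shown here, the only measured step, a 5.0-fold higher number from compound 1 to compound 2 (0.70 log units; beyond the scatter), exchanges a group at that same place and lies beyond the scatter. This single step is thin guidance for a group not yet tested, but a further modest move towards a higher number in this assay is expected. The expected step is a 10-fold higher number from compound 2 to compound 3 (1.00 log units; beyond the scatter). Compound 3 is estimated at 1 uM, with an expected range of 0.15 uM to 10 uM.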

Compound 3, concentration for half-maximal effect: 0.3 uM
Compound 3: the middle estimate sits 3.3-fold (0.52 log units) above what was measured, and the stated range covers the measured number.
By their numbers in this assay, from the lowest: compound 1; then compound 2; then compound 3.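

In this assay the number at this position keeps changing with the group placed there: butylamino gives a 3.0-fold higher number from compound 2 to compound 3 (0.48 log units; beyond the scatter) and, against methylsulfanyl, a 15-fold higher number from compound 1 to compound 3 (1.18 log units; beyond the scatter) as the overall change. Compound 3 therefore has the highest number of the three. This exchange lengthens the chain and also replaces the ethoxy oxygen with a nitrogen carrying a hydrogen-bond donor, so two changes arrive together, and no measurement here explains the step.

Which of the two changes matters remains open. Butoxy would keep the longer chain without that nitrogen, while methylamino would keep the nitrogen on a shorter chain.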